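Adding Fluoro to Compound 2: A Cytotoxicity Expectation

The compounds below may be only part of what the source reports. "The series", "measured", "known", "first", "only" and "open" are said of these compounds alone.

In an ADME assay on MT4 cells (Homo sapiens) for cytotoxicity, read by MTT assay, with a stated time of 4 days (a higher number here means that more compound is tolerated, a lower number that less compound is tolerated), compound 2 (`Nc1ccc2oc(-c3ccccc3)c(O)c(=O)c2c1`) gives 217000 nM. Compound 3 (`COc1ccccc1-c1oc2ccc(N)cc2c(=O)c1O`) gives 222000 nM, and compound 1 (`Nc1ccc2oc(-c3ccc(F)cc3)cc(=O)c2c1`) gives 264000 nM. Compound 2 therefore stands level with the other two, since all three numbers lie within the usual scatter of one another.

The next structure, compound 4 (`Nc1ccc2oc(-c3ccc(F)cc3)c(O)c(=O)c2c1`), has not yet been measured. It is compound 2 with one small edit: fluoro in place of hydrogen on an aromatic carbon. In words, fluoro takes the place of hydrogen on an aromatic carbon, para to a large group.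

Going by the values given here, only one measured step bears directly on this kind of edit. It is a 1.0-fold higher number from compound 2 to compound 3 (0.01 log units; within the scatter), where methoxy replaces hydrogen on an aromatic carbon, and it stays within the scatter. It is a different group, so it is only a loose guide. Compound 1 also carries a fluoro group and gives 264000 nM, which is level with compound 2, though the two differ elsewhere in structure. Neither comparison points to a real shift in this assay, in either direction.

The estimated change is a 1.1-fold higher number from compound 2 to compound 4 (0.03 log units; within the scatter), so no step beyond the scatter is expected. For compound 4 the expected value is 230000 nM, with an estimated range from 140000 nM to 350000 nM.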

Compound 4, half-maximal cytotoxic concentration: 92600 nM
Beside the measured number, compound 4's estimate is 2.5-fold (0.40 log units) above it; measured number outside the range, below it.
By their numbers in this assay, from the lowest: compound 4; then compounds 2, 3 and 1 (each within the scatter of the next).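

Fluoro in place of hydrogen on an aromatic carbon, para to a large group, gives a 2.3-fold lower number from compound 2 to compound 4 (0.37 log units; beyond the scatter) in this assay and so shows that this position can affect how much compound is tolerated, whereas the methoxy edit gave only a 1.0-fold higher number from compound 2 to compound 3 (0.01 log units; within the scatter) and stayed within the scatter. The hydroxy edit gives a 2.9-fold lower number from compound 1 to compound 4 (0.45 log units; beyond the scatter) on a core that already carries fluoro, so compound 4, which has both groups, has a lower number than compound 2, which has only the hydroxy, and compound 1, which has only the fluoro. Nothing here explains why the number falls with either edit.

The compounds shown leave open whether this fall is particular to fluoro or would also follow from chloro, methyl or an amine at the same place. They also leave open how much fluoro changes the number when the hydroxy is absent, since the step from a parent with neither group to compound 1 cannot be read from this set, and so whether the two groups simply add up or act together remains unsettled.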